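The source may report more compounds than this note shows. Statements on the series, on what has been measured and on what is new or still open speak of the compounds shown alone.

Working notes on the series. In a functional assay on MDA-MB-231 cells (Homo sapiens) for antiproliferative activity, read by luminescence, with a stated time of 72 h (a lower number here means a stronger inhibitor, a higher number a weaker inhibitor), compound 1 (`CC(C)(C)OC(=O)Oc1ccc(Cn2ccnc2)c2cccnc12`) gives 31500 nM as the higher of the two numbers available, which makes it the weaker inhibitor of that pair. Compound 3 (`Oc1ccc(Cn2cnc3ccccc32)c2cccnc12`) gives 4700 nM in this assay and sits lower by a margin beyond the scatter. Compound 2 (`Cc1cc2ncn(Cc3ccc(O)c4ncccc34)c2cc1C`) adds nothing to the comparison, since its entry reads "not determined" (no result reported) and carries no result.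

Compound 4 (`O=C(Oc1ccc(Cn2ccnc2)c2cccnc12)c1ccccc1`) is the next to be read in this assay. Its difference from compound 1 is phenyl in place of tert-butoxy on a carbonyl carbon and amounts to phenyl in place of tert-butoxy on a carbonyl carbon, or tert-butoxycarbonyl to benzoyl when cut one bond further out. Among the measured compounds shown here, no pair of measured compounds isolates this change, so the expectation is loose. Compound 3 at 4700 nM shows that numbers lower than that of compound 1 occur in the series, although the two differ in more than one place. A modest move to a lower number is therefore expected, and the estimated size is a 2.3-fold lower number from compound 1 to compound 4 (0.35 log units; beyond the scatter) in this assay with wide uncertainty. For compound 4 the estimated value is 14000 nM with an expected range from 4000 nM to 45000 nM in this measurement.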

Compound 4, half-maximal inhibitory concentration: 12300 nM
Estimate against measurement, compound 4: 1.1-fold (0.06 log units) above; measured number inside the range.
By their numbers in this assay, from the lowest: compound 3; then compound 4; then compound 1.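

In this assay, among the compounds shown here, phenyl in place of tert-butoxy on a carbonyl carbon gives a 2.6-fold lower number from compound 1 to compound 4 (0.41 log units; beyond the scatter), the first reading of how the series responds to a change at this position. The response is modest but lies beyond the scatter, so the group on this carbonyl carbon does bear on the read-out, and a six-membered aromatic ring of carbon only is accepted there with no loss. For the compounds shown here, the single step, however, exchanges a group with no ring and with a hydrogen-bond acceptor for a ring without one, so it cannot separate these differences from one another, and nothing at hand accounts for the shift.

Still open, on these data alone, is whether a saturated ring such as cyclohexyl, a short chain such as methyl, or a phenyl carrying an amine or a carboxylic acid on the same carbonyl carbon would move the number further in either direction. Also open, as far as these compounds go, is whether the change from tert-butoxycarbonyl to benzoyl would give a step of similar size on the core of compound 3.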